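Cytotoxicity notes on a thioether series toward compound 4

The source may hold more compounds than are shown below. What is called first, only, known or untested is meant among the compounds shown, and "the series" means these compounds.

Compound 1 `Cc1ccc(CSc2nc(Cc3c(F)cccc3F)c(C)c(=O)[nH]2)c(C)c1` is tested in an ADME assay on MT4 cells (Homo sapiens) for cytotoxicity, read by MTT assay; a lower number here means that less compound is tolerated, a higher number that more compound is tolerated. In this assay compound 1 gives only a limit, > 65000 nM. Compound 2 `Cc1cc(C)cc(CSc2nc(Cc3c(F)cccc3F)c(C)c(=O)[nH]2)c1` likewise returns a limit, > 65000 nM. Compound 3 `Cc1c(Cc2c(F)cccc2F)nc(SCc2cccnc2)[nH]c1=O` also returns a limit, > 70000 nM, and so stands level with the other two as far as the numbers can tell. The steps a step that the two limits leave unreadable from compound 1 to compound 2, a step that the two limits leave unreadable from compound 1 to compound 3 and a step that the two limits leave unreadable from compound 2 to compound 3 thus have no readable size; every value rests at the limit of > 65000 nM in this assay, at which 2 of the 3 values shown sit, or (the limit of > 70000 nM in this assay, at which 1 of the 3 values shown sits). Compound 4 `Cc1c(Cc2c(F)cccc2F)nc(SC(C)C)[nH]c1=O` differs from compound 3 by isopropyl in place of (pyridin-3-yl)methyl on a sulfur. The measured steps all exchange one ring for another on the same saturated chain carbon and none is readable, so nothing points to a change for compound 4 beyond the scatter. Compound 4 is therefore expected to give 70000 nM, in the range 35000 nM to 150000 nM. The step this estimate means is a number no higher from compound 3 to compound 4 (the limit leaves the size open), expected to stay within the scatter.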

Compound 4, half-maximal cytotoxic concentration: > 77000 nM
Compound 4: a limit, no number (the forecaster's own chance of this, stated with the estimate: 80%); at least 1.1-fold (0.04 log units) between middle value and limit.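

In this assay compound 4 gives only a limit, > 77000 nM, so its steps from compound 1, compound 2 and compound 3 cannot be read. The compounds shown leave open where cytotoxicity begins for any of the four, and whether the group on the sulfur alters it.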